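A Methyl Added on the Propanoyl Chain of Compound 1

The source may hold more compounds than are shown below. What is called first, only, known or untested is meant among the compounds shown, and "the series" means these compounds.

Compound 1 `CCC(=O)c1ccc(OCCCCOc2ccc(F)c(C(=O)O)c2)c(C)c1O` is the starting point of this account. Going by the values given here, in an assay on HEK293 cells for positive allosteric modulation of metabotropic glutamate receptor 3 (Rattus norvegicus), read by thallium flux, with a stated time of 2.5 min (a lower number here means that less compound is needed, a higher number that more compound is needed for the effect), compound 1 gives "not determined" (no result reported), so it stands without a single number among the three compounds described here, and no step can be drawn from it. Compound 2 `CC(=O)c1ccc(OCCCCOc2cccc(C(=O)O)c2C)c(C)c1O` also gives "not determined" (no result reported) in this assay. Compound 3 `Cc1c(OCCCCOc2ccc(C(=O)O)cc2F)ccc(C(=O)CC2CCCC2)c1O` gives > 10000 nM in this assay, and this is a limit of the assay rather than a number. The only reported result in the set is therefore (the limit of > 10000 nM in this assay, at which 1 of the 3 values shown sits).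

Compound 4 `Cc1c(OCCCCOc2ccc(F)c(C(=O)O)c2)ccc(C(=O)C(C)C)c1O` differs from compound 1 by methyl in place of hydrogen on a saturated chain carbon bound to a carbonyl carbon and a saturated chain carbon, which, cut one bond further out, reads propanoyl to isopropylcarbonyl. Among the compounds with values here, no pair of measured compounds differs in one place, so the size of this step cannot be read from any measured pair. In this assay one expects no shift beyond the usual scatter, with the direction open, since a single methyl enters on a saturated chain carbon and nothing else changes. The one reported result in the set weighs toward a weak or unresolved outcome. Compound 4 is therefore expected to give about 8000 nM in this assay, within a range from 2000 nM to 30000 nM, with a real chance that only a limit is reported.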

Compound 4, half-maximal effective concentration: > 10000 nM
Compound 4 was reported as a limit; the forecaster's own chance of this, stated with the estimate: 60%; middle value at least 1.2-fold (0.09 log units) away from the limit.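

In this assay compound 4 gives > 10000 nM, which is a limit of the assay and not a number. Going by these compounds alone, compound 1 has no reported result, so no step between compound 1 and compound 4 can be read. The compounds shown leave open what methyl in place of hydrogen on this saturated chain carbon does to the half-maximal effective concentration in this assay.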